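Swapping an ester chain for a phenylethyl group on a shared core

The source may report more compounds than this note shows. Statements on the series, on what has been measured and on what is new or still open speak of the compounds shown alone.

Measured compounds:
Compound 1, `Cc1ncc(CO)c2c(Nc3ccccc3)c(NCc3ccccc3)oc12`: 1680 nM
Compound 2, `CCOC(=O)CNc1oc2c(C)ncc(CO)c2c1Nc1ccccn1`: "not active" (no number reported)
Compound 3, `CCCCCNc1oc2c(C)ncc(CO)c2c1Nc1cccc(F)c1`: 370 nM

All three share the same core and differ in the groups attached to its two amine nitrogens. In a functional assay on HEK293 cells for agonist activity at Toll-like receptor 8 (Homo sapiens), read by reporter gene assay (on this read-out higher numbers stand for an effect only at larger amounts of compound and lower numbers for an effect already at smaller amounts), compound 1 gives 1680 nM and compound 3 gives 370 nM, while compound 2 is reported as "not active" (no number reported) with no number attached to it. Compound 2 therefore stands apart from the other two: it carries an ester-bearing chain on the ring nitrogen, and the assay reports no measurable effect for it.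

Compound 4, `Cc1ncc(CO)c2c(Nc3ccccn3)c(N[C@@H](C)c3ccccc3)oc12`, keeps the same core and the same pyridinylamino group as compound 2, but changes the other substituent: 1-phenylethyl in place of (ethoxycarbonyl)methyl on a nitrogen on an aromatic ring. Nothing in the measured set compares these two groups directly on an otherwise identical scaffold, so the size of the step from compound 2 to compound 4 in this assay cannot be taken from a recorded step. The new group, however, resembles the benzyl group of compound 1 more than the ester chain of compound 2, and compound 1 does register an effect at 1680 nM.

Compound 4 is therefore expected to show an effect, with an estimated value of 1200 nM in this assay, somewhere between 250 nM and 6000 nM.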

Compound 4, half-maximal effective concentration: 4270 nM
Beside the measured number, compound 4's estimate is 3.6-fold (0.55 log units) below it, and the stated range covers the measured number.
By their numbers in this assay, from the lowest: compound 3; then compound 1; then compound 4.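

No new step can be read from compound 4: its one-place neighbour, compound 2, carries no number in this assay and compound 1 and compound 3 each differ from compound 4 in more than one place. Nothing measured here accounts for the result. The compounds shown leave open what swapping in the 1-phenylethyl group alone does to the value.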